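A few compounds are considered here, and "the series" means these few. Any claim that something is new, unique, unknown or untested is made for them only; others in the source may bear on it.

In an in vitro ADME assay on microsomes from liver (Mus musculus) for pharmacokinetics, read by LC-MS, with a stated time of 10 min, tested at 1 uM (a higher number here means faster removal of the compound, a lower number slower removal), the three measured compounds stand as follows:

Compound 1 `CN1C[C@H](C(=O)Nc2ccccc2)[C@@H](c2ccc(/C=C/C(=O)Nc3ccccc3N)cc2)C1`: 67 mL/min/kg
Compound 2 `COc1cccc(NC(=O)[C@H]2CN(C)C[C@@H]2c2ccc(/C=C/C(=O)Nc3ccccc3N)cc2)c1`: 65 mL/min/kg
Compound 3 `CN1C[C@H](C(=O)Nc2ccc(F)cc2F)[C@@H](c2ccc(/C=C/C(=O)Nc3ccccc3N)cc2)C1`: 27 mL/min/kg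

Compound 1 carries the largest figure of the three, yet the step of a 1.0-fold lower number from compound 1 to compound 2 (0.01 log units; within the scatter) lies within the scatter, so compound 1 and compound 2 cannot be told apart, whereas the step of a 2.5-fold lower number from compound 1 to compound 3 (0.39 log units; beyond the scatter) is beyond it, as is a 2.4-fold lower number from compound 2 to compound 3 (0.38 log units; beyond the scatter).

Compound 4 `CN1C[C@H](C(=O)Nc2ccccn2)[C@@H](c2ccc(/C=C/C(=O)Nc3ccccc3N)cc2)C1` differs from compound 1 at the amide-type nitrogen: pyridin-2-yl in place of phenyl on an amide-type nitrogen. Among the compounds with values here, none of the measured steps exchanges the phenyl for a ring holding a hetero atom. The nearest comparison is the replacement of the same phenyl by the 2,4-difluorophenyl, a modest lowering, while adding a methoxy left the number unchanged. Compound 4 is therefore expected to sit close to compound 1 or somewhat lower, with a step of a 1.3-fold lower number from compound 1 to compound 4 (0.13 log units; within the scatter) and a wide range. The estimate for compound 4 is 50 mL/min/kg, between 25 mL/min/kg and 90 mL/min/kg.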

Compound 4, clearance: 40 mL/min/kg
Beside the measured number, compound 4's estimate is 1.3-fold (0.10 log units) above it; the measured number falls inside the stated range.
By their numbers in this assay, from the lowest: compounds 3, 4, 2 and 1 (each within the scatter of the next, the first and the last beyond it).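

Within the data shown here, with pyridin-2-yl, a ring holding a hetero atom stands on the amide-type nitrogen for the first time, and in this assay this exchange for phenyl, which adds a hydrogen-bond acceptor, gives no change that can be told from scatter (a 1.7-fold lower number from compound 1 to compound 4 (0.22 log units; within the scatter)). Compound 4 also cannot be separated from either of the other two compounds (a 1.6-fold lower number from compound 2 to compound 4 (0.21 log units; within the scatter); a 1.5-fold higher number from compound 3 to compound 4 (0.17 log units; within the scatter)), so it links compound 1 and compound 3 by steps within the scatter, although those two compounds lie beyond the scatter of each other. Nothing available gives a reason for these results.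

The compounds shown leave open whether the place of the ring nitrogen matters, as pyridin-3-yl or pyridin-4-yl would show. They also leave open how a pyrimidin-2-yl ring or a cyclohexyl group on this nitrogen would compare.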